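Same Ester Swap on a Second Core

The compounds below may be only part of what the source reports. "The series", "measured", "known", "first", "only" and "open" are said of these compounds alone.

Compound 1 `CC1=C(C(=O)OCC(C)C)C(c2cccs2)NC(=O)N1`: 25%
Compound 2 `CC1=C(C(=O)OC(C)(C)C)C(c2cccs2)NC(=O)N1`: 26%
Compound 3 `CC1=C(C(=O)OCC(C)C)C(c2ccoc2)NC(=S)N1`: 12%

All three were tested in an assay on membranes from CHO cells for displacement of a labelled ligand from adenosine receptor A1 (Homo sapiens), read by scintillation counting, with a stated time of 60 min, tested at 1 uM; a lower number here means less inhibition, a higher number more inhibition at the concentration tested (going by the name of the read-out). In this assay compound 1 gives 25%, and compound 2 gives 26%. The two differ in one place only, (tert-butyl in place of isobutyl on an oxygen next to a carbonyl group), and the step is a number 1 percentage points higher from compound 1 to compound 2 (within the scatter), so the swap of the ester group leaves the read-out essentially unchanged here.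

Compound 3 gives 12% in this assay, the lowest of the three numbers and beyond the scatter from both others. How the core of compound 3 differs from the core of compound 1 is not broken down here.

Compound 4 `CC1=C(C(=O)OC(C)(C)C)C(c2ccoc2)NC(=S)N1` has not yet been measured. It differs from compound 3 by tert-butyl in place of isobutyl on an oxygen next to a carbonyl group, the same change, at the same place, as that from compound 1 to compound 2. Since a step of the same kind on the first core amounted to a number 1 percentage points higher from compound 1 to compound 2 (within the scatter), a step of about a number 1 percentage points higher from compound 3 to compound 4 (within the scatter) is expected on the second core. Compound 4 is therefore estimated to give about 13% in this assay, most likely falling in the range from 3% to 25%.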

Compound 4, a percentage reported as inhibition, at one concentration (the size of the read-out at that concentration, not a potency): 18%
Estimate against measurement, compound 4: 5 percentage points below, and the stated range covers the measured number.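

Replacing isobutyl with tert-butyl on an oxygen next to a carbonyl group on the second core gives, in this assay, a number 6 percentage points higher from compound 3 to compound 4 (within the scatter). Set beside the same change on the first core, the two steps agree: the same change on two cores in this assay, a number 1 percentage points higher (within the scatter) from compound 1 to compound 2 and a number 6 percentage points higher (within the scatter) from compound 3 to compound 4, 5 percentage points apart, within the scatter of two such steps

So across these two pairs the change carries from one core to the other without a detectable difference, and on neither core does it move the read-out beyond the usual scatter; this does not prove that the two cores respond identically, as a small real difference could hide within that scatter, and two pairs tested at a single concentration say nothing about potency or about other cores.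

The compounds shown leave open whether a longer chain, a carboxylic acid or an amide in place of the ester group would shift the read-out beyond the scatter. They also leave open which part of the difference between the two cores matters, as no pair shown changes the core in one place only.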